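The source may hold more compounds than are shown below. What is called first, only, known or untested is meant among the compounds shown, and "the series" means these compounds.

Measured so far:
compound 1 `Cc1c(-c2ccccc2)sc(N)c1C(=O)c1ccc(Cl)cc1`, an assay on CHO cells for displacement of a labelled ligand from adenosine receptor A1 (Homo sapiens), read by scintillation counting, tested at 10 uM (a higher number here means more inhibition at the concentration tested (going by the name of the read-out), a lower number less inhibition), 1%
compound 2 `COc1ccccc1-c1sc(N)c(C(=O)c2ccc(Cl)cc2)c1CC(C)(C)C`, this assay 1%

Compound 1 stands level with compound 2 at the digits shown; in this assay compound 1 gives 1% and compound 2 gives 1%, a gap that lies within the scatter of repeated measurements, so the inhibition in this assay is level for the two and neither number can be called higher or lower than the other. Both share a core that carries a free amine, a chlorophenyl carbonyl and a phenyl, and both sit at the floor of the read-out.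

Compound 3 `CC(C)(C)Cc1c(-c2ccccc2)sc(N)c1C(=O)c1ccc(Cl)cc1` is not yet measured. It differs from compound 1 in one place:
tert-butyl in place of hydrogen on a saturated chain carbon bound to an aromatic carbon

Among the measured compounds shown here, no step between measured compounds is available for this change. What the two measured compounds offer is indirect: compound 2 already carries the tert-butyl on this same chain carbon, together with a methoxy on the phenyl, and in this assay compound 2 gives 1%, level with compound 1. The expectation for this assay is therefore a step from compound 1 to compound 3 of a number 1 percentage points higher from compound 1 to compound 3 (within the scatter), no change beyond the scatter in either direction. Compound 3 is estimated at 2%, in a range from -8% to 12%.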

Compound 3, a percentage reported as inhibition, at one concentration (the size of the read-out at that concentration, not a potency): 1%
The estimate for compound 3 lay 1 percentage points above the measured number; the measured number falls inside the stated range.
By their numbers in this assay, from the lowest: compounds 1, 2 and 3 (each within the scatter of the next).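

In this assay, tert-butyl in place of hydrogen on a saturated chain carbon bound to an aromatic carbon can now be read as a direct step (no change at the digits printed from compound 1 to compound 3 (within the scatter)), so this change, which also reads as methyl to neopentyl, has a measured result on the shared core. Hydrogen in place of methoxy on an aromatic carbon can also be read on its own for the first time (no change at the digits printed from compound 2 to compound 3 (within the scatter)), which separates it from the tert-butyl change that the earlier pair carried together with it. Nothing in hand speaks to what lies behind these readings.

Going by these compounds, all of these readings come from a single tested concentration and sit at the floor of the read-out, so it remains open whether any group on this chain carbon can raise inhibition at all, with a carboxylic acid, a primary amine or a longer chain such as hexyl as possible probes. On these data alone, it also remains open whether a hydroxyl or a chlorine on the phenyl would move the read-out, or whether the two changes read here would stay silent on a core that gives a higher starting value.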